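Compound 3: a new group on the carbonyl carbon

The source may hold more compounds than are shown below. What is called first, only, known or untested is meant among the compounds shown, and "the series" means these compounds.

In an ADME assay on HEK-293T cells (Homo sapiens) for cytotoxicity, read by luminescence, with a stated time of 24 h (a lower number here means that less compound is tolerated, a higher number that more compound is tolerated), compound 2 `COc1ccc(Cn2c(C(=O)N3CCNCC3)cc3sccc32)cc1` gives > 100000 nM, which is a limit of the assay. Compound 1 `COc1ccc(Cn2c(C(=O)NCc3ccccc3)cc3sccc32)cc1` gives > 100000 nM, which is also a limit. The evidence so far is the limit of > 100000 nM in this assay, at which 2 of the 2 values shown sit. Compound 3 `COc1ccc(Cn2c(C(=O)N3CCC(C(=O)O)CC3)cc3sccc32)cc1` carries 4-carboxypiperidin-1-yl in place of piperazin-1-yl on a carbonyl carbon. Going by the values given here, because a step that the two limits leave unreadable from compound 1 to compound 2 is the only measured step, it offers no size to carry over, and no step beyond the scatter is expected in this assay. The expected change is a number no higher from compound 2 to compound 3 (the limit leaves the size open). For compound 3 the estimate is 100000 nM, within an expected range of 40000 nM to 200000 nM.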

Compound 3, half-maximal cytotoxic concentration: > 100000 nM
Compound 3: only a limit was reported; the forecaster's own chance of this, stated with the estimate: 85%; the middle value lies on the limit itself.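

Going by these compounds alone, compound 1, compound 2 and compound 3 all sit at the same limit in this assay, so no step among them can be read. These compounds leave open whether the groups on the carbonyl carbon differ in how much compound is tolerated.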